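Para Nitro on the Pendant Phenyl of a Pyrazole Acid

The source may report more compounds than this note shows. Statements on the series, on what has been measured and on what is new or still open speak of the compounds shown alone.

Measured compounds:
- compound 1, `CCOC(=O)c1nn(-c2ccccc2)c(-c2ccccc2)c1CNC(C)(C)C`, in a functional assay on U-251 cells (Homo sapiens) for inhibition, read by sulforhodamine B assay, with a stated time of 48 h (on this read-out lower numbers stand for stronger inhibition of growth and higher numbers for weaker inhibition of growth), gives 81500 nM; 441000 nM (2 entries)
- compound 2, `CC(C)(C)NCc1c(C(=O)O)nn(-c2ccccc2)c1-c1ccc(Cl)cc1`, gives in this assay only a limit, > 652000 nM
- compound 3, `CC(C)(C)NCc1c(C(=O)O)nn(-c2ccccc2)c1-c1ccccc1`, gives in this assay only a limit, > 716000 nM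

Compound 3 is the ester-free acid of the shared core with an unsubstituted phenyl. In this assay compound 3 reaches no number at all: its entry is a limit, and of the three values shown in this assay, one further is also a limit, so the acid sits at the weak end of what the assay can report. Among the measured compounds shown here, compound 1, the ethyl ester, is the only member with actual numbers, and those two entries scatter widely.

Compound 4, `CC(C)(C)NCc1c(C(=O)O)nn(-c2ccccc2)c1-c1ccc([N+](=O)[O-])cc1`, differs from compound 3 in one place: nitro in place of hydrogen on an aromatic carbon.

For the measured compounds named here, the only one-step comparison available is a step that the two limits leave unreadable from compound 2 to compound 3; both ends are limits, so it says nothing about the size or direction of a change on that phenyl ring. No measured step therefore bears on the nitro for hydrogen exchange, and none gives a reason to expect a move beyond the scatter in this assay.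

Compound 4 is accordingly expected to give roughly 700000 nM, within 250000 nM to 1500000 nM, most likely as another limit; the estimated step is an at least 1.0-fold lower number from compound 3 to compound 4 (0.00 log units; that floor lies within the scatter).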

Compound 4, concentration for 50% growth inhibition: > 634000 nM
Compound 4 was reported as a limit; the forecaster's own chance of this, stated with the estimate: 70%; the middle value is on the limit's open side.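

Compound 2, compound 3 and compound 4 all stand in this assay only as limits, and the steps from compound 3 to compound 4 and from compound 2 to compound 4 cannot be read. The compounds shown leave open whether hydrogen, chloro or nitro on that phenyl ring makes any difference to growth inhibition by the acid.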